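Cyclopropylsulfamoyl to trifluoromethyl: microsomal clearance note

A few compounds are considered here, and "the series" means these few. Any claim that something is new, unique, unknown or untested is made for them only; others in the source may bear on it.

Measured so far:
compound 1 `CNS(=O)(=O)c1ccc(-c2cnc(N)c(-c3ccc(OC)nc3)c2)cc1` — 9.6 mL.min-1.g-1
compound 2 `COc1ccc(-c2cc(-c3ccc(S(=O)(=O)NC4CC4)cc3)cnc2N)cn1` — 15 mL.min-1.g-1

Among the measured compounds shown here, in an in vitro ADME assay on microsomes from liver (Homo sapiens) for metabolic stability (on this read-out lower numbers stand for slow clearance and higher numbers for fast clearance), compound 2 gives 15 mL.min-1.g-1, the higher of the two numbers recorded; compound 1 sits nearest, and the one recorded step a 1.6-fold higher number from compound 1 to compound 2 (0.19 log units; within the scatter) is within the scatter, so the two compounds cannot be ordered on this read-out.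

Compound 3 `COc1ccc(-c2cc(-c3ccc(C(F)(F)F)cc3)cnc2N)cn1` has not been measured. It differs from compound 2 by trifluoromethyl in place of cyclopropylsulfamoyl on an aromatic carbon. For the measured compounds named here, no measured step bears on this kind of change: the only recorded step concerns a substituent on the sulfonamide nitrogen, not the removal of the whole group, and it was within the scatter. The basis for an expectation is therefore thin. Compound 3 is expected at 25 mL.min-1.g-1, with a range from 9 mL.min-1.g-1 to 65 mL.min-1.g-1. This corresponds to an estimated step of a 1.7-fold higher number from compound 2 to compound 3 (0.22 log units; within the scatter), with wide uncertainty in either direction.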

Compound 3, intrinsic clearance in microsomes: 6.1 mL.min-1.g-1
Compound 3: the middle estimate sits 4.1-fold (0.61 log units) above what was measured, outside the stated range (below it).
By their numbers in this assay, from the lowest: compounds 3, 1 and 2 (each within the scatter of the next, the first and the last beyond it).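

In this assay, among the compounds shown here, the whole sulfonamide group on this aromatic carbon can be exchanged, and trifluoromethyl in place of cyclopropylsulfamoyl gives a 2.5-fold lower number from compound 2 to compound 3 (0.39 log units; beyond the scatter) as the first step beyond the scatter. The corresponding exchange for methylsulfamoyl gives a 1.6-fold lower number from compound 1 to compound 3 (0.20 log units; within the scatter) and so does not separate those two compounds, which means the reading of this change depends on the sulfonamide it is compared with. Nothing available explains either step.

The compounds shown leave open whether the step at this carbon follows the loss of the sulfonamide or the arrival of trifluoromethyl. A nitrile, a carboxylic acid or a simple amine at the same carbon on the shared core would help separate those two readings.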